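Swapping One Aryl Ring for Another in a Cell Assay

A few compounds are considered here, and "the series" means these few. Any claim that something is new, unique, unknown or untested is made for them only; others in the source may bear on it.

The measure here is a functional assay on SK-MEL-5 cells (Homo sapiens) for inhibition, read by sulforhodamine B assay, with a stated time of 48 h, tested at 10 uM; on this read-out lower numbers stand for less inhibition and higher numbers for more inhibition at the one concentration tested (going by the name of the read-out). Compound 1 `Brc1cn2ccnc2c(-c2ccc3ncn(C4CCCCC4)c3c2)n1` gives 13.4% in this assay. Within the data shown here, compound 2 `CC(=O)c1ccc(-c2cn3ccnc3c(-c3ccc4ncn(C5CCCCC5)c4c3)n2)cc1` gives 24.8%, the higher of the two numbers seen so far; the only measured step, a number 11.4 percentage points higher from compound 1 to compound 2 (beyond the scatter), shows this. Compound 3 `Fc1ccccc1-c1cn2ccnc2c(-c2ccc3ncn(C4CCCCC4)c3c2)n1` is not yet measured; it differs from compound 2 by 2-fluorophenyl in place of 4-acetylphenyl on an aromatic carbon. That measured step concerns a change from bromo to an aryl ring, not the exchange of one aryl ring for another, so it bears on the present step only loosely: it shows that an aryl group at the same place can lift inhibition by a modest amount, with nothing yet on how a different aryl ring compares. The expected step is a number 5.8 percentage points lower from compound 2 to compound 3 (within the scatter), a small drop that may well stay within the scatter. Compound 3 is therefore estimated at 19%, with a range from 6% to 34%.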

Compound 3, a percentage reported as inhibition, at one concentration (the size of the read-out at that concentration, not a potency): 6.5%
Beside the measured number, compound 3's estimate is 12.5 percentage points above it; the range from low to high includes it.
By their numbers in this assay, from the lowest: compounds 3 and 1 (each within the scatter of the next); then compound 2.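

In this assay an aryl ring at this position does not lift inhibition simply by being an aryl ring: exchanging 4-acetylphenyl for 2-fluorophenyl gives a number 18.3 percentage points lower from compound 2 to compound 3 (beyond the scatter) and so shows that the choice of ring matters. The exchange of bromo for 2-fluorophenyl gives a number 6.9 percentage points lower from compound 1 to compound 3 (within the scatter) and so does not separate those two groups. Nothing measured here gives a reason for the gap between the two aryl rings.

Still open, as far as these compounds go, is whether the acetyl group itself or its place on the ring accounts for that gap, as the two rings differ both in the group they carry and in where it sits. A plain phenyl ring, or a phenyl ring carrying an amine or a carboxylic acid, would help to tell these readings apart.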